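A few compounds are considered here, and "the series" means these few. Any claim that something is new, unique, unknown or untested is made for them only; others in the source may bear on it.

Measured so far:
- compound 1 `CCN(CC)CCCn1c(N)c(-c2nc3ccccc3n2C)c2nc(C#N)c(C#N)nc21` — 4470 nM
- compound 2 `CCN(CC)CCn1c(N)c(-c2nc3cc(Cl)ccc3[nH]2)c2nc(C#N)c(C#N)nc21` — 9290 nM

Two compounds of the series have been run in a functional assay on HL60/MX2 cells (Homo sapiens) for antiproliferative activity, read by MTT assay, with a stated time of 48 h; a lower number here means a stronger inhibitor, a higher number a weaker inhibitor. Compound 1 gives 4470 nM; compound 2 gives 9290 nM. Compound 2 has the highest of the two numbers; its nearest neighbour is compound 1, whose number is lower by a margin that lies beyond the usual scatter. Within the data shown here, compounds 1 and 2 differ in more than one place, so no single step is defined between them and their gap is only a comparison of two values.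

Compound 3 `CCN(CC)CCCn1c(N)c(-c2nc3cc(Cl)ccc3[nH]2)c2nc(C#N)c(C#N)nc21` has not been measured. It differs from compound 2 in one place: (diethylamino)methyl in place of diethylamino on a saturated chain carbon, two bonds along the chain from an aromatic nitrogen. Compound 3 shares the chain length of compound 1 and the substitution of compound 2, so the pair of measured values gives only loose guidance. A small step is expected, in the direction of a lower number and within or just at the scatter: a 1.4-fold lower number from compound 2 to compound 3 (0.16 log units; within the scatter). Compound 3 is therefore estimated at 6500 nM in this assay, with a range from 2500 nM to 16000 nM.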

Compound 3, half-maximal inhibitory concentration: 2460 nM
For compound 3 the middle estimate is 2.6-fold (0.42 log units) above the measured one; the whole stated range lies above it.
By their numbers in this assay, from the lowest: compounds 3 and 1 (each within the scatter of the next); then compound 2.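

In this assay, among these compounds, the step (diethylamino)methyl in place of diethylamino on a saturated chain carbon, two bonds along the chain from an aromatic nitrogen, gives the first single-place reading of this position (a 3.8-fold lower number from compound 2 to compound 3 (0.58 log units; beyond the scatter)), and that step lies beyond the scatter, so the series responds to going from 2-(diethylamino)ethyl to 3-(diethylamino)propyl with the rest of the structure held fixed. With the 3-(diethylamino)propyl chain held, 5-chloro-1H-benzimidazol-2-yl in place of 1-methyl-1H-benzimidazol-2-yl on an aromatic carbon stays within the scatter (a 1.8-fold lower number from compound 1 to compound 3 (0.26 log units; within the scatter)), so on this chain the two aromatic substituents are not told apart in this assay. The data shown give no measured basis for explaining the chain step.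

One pair defines the chain effect, so the compounds shown do not say whether a longer chain such as 4-(diethylamino)butyl would extend the trend or reverse it. They also leave open whether the same step holds with a different terminal amine, such as dimethylamino, piperidine or morpholine, in place of the diethylamino end.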